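Cytotoxicity limits in the series and the dimethoxyphenyl step

The source may report more compounds than this note shows. Statements on the series, on what has been measured and on what is new or still open speak of the compounds shown alone.

Of the compounds shown here, three have been tested in an ADME assay on Vero cells (Chlorocebus sabaeus) for cytotoxicity, read by MTT assay, with a stated time of 72 h (on this read-out higher numbers stand for lower toxicity in this test and lower numbers for higher toxicity in this test), and each came back only as a limit. Compound 1 `NS(=O)(=O)c1ccc(N2N=C(c3ccc(O)cc3)CC2c2cn(-c3ccccc3)nc2-c2ccccc2)cc1` gives > 160000 nM, which is a limit of the assay. Compound 2 `Cc1ccc(C2=NN(c3ccc(S(N)(=O)=O)cc3)C(c3cn(-c4ccccc4)nc3-c3ccc(F)cc3)C2)cc1` gives > 90600 nM, again a limit. Compound 3 `Cc1ccc(C2=NN(c3ccc(S(N)(=O)=O)cc3)C(c3cn(-c4ccccc4)nc3-c3ccc(C)cc3)C2)cc1` gives > 41400 nM, also a limit, so it stands among three limit values with no numbers to order. The step that the two limits leave unreadable from compound 2 to compound 3 therefore cannot be read. Compound 4 `COc1cccc(C2=NN(c3ccc(S(N)(=O)=O)cc3)C(c3cn(-c4ccccc4)nc3-c3ccc(C)cc3)C2)c1OC` differs from compound 3 by 2,3-dimethoxyphenyl in place of 4-methylphenyl on a carbon with a double bond to nitrogen. Going by the values given here, no measured step bears on this change; the limits the limit of > 41400 nM in this assay, at which 1 of the 3 values shown sits, and the limit of > 90600 nM in this assay, at which 1 of the 3 values shown sits, show only that no toxicity was reached in this assay. The step that the limit leaves unreadable from compound 3 to compound 4 is expected to stay within the scatter, with a further limit likely. Compound 4 is estimated at 60000 nM, between 20000 nM and 200000 nM.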

Compound 4, half-maximal cytotoxic concentration: > 57300 nM
Compound 4 gave a limit, no number (the forecaster's own chance of this, stated with the estimate: 75%); the middle value is on the limit's open side.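

Compound 3 and compound 4 both remain limits, not numbers, so the step between them cannot be read. The compounds shown leave open where any of the four reaches a half-maximal cytotoxic concentration, and whether 2,3-dimethoxyphenyl in place of 4-methylphenyl shifts it.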